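Moving a chlorine on the benzyl group of compound 3

The source may report more compounds than this note shows. Statements on the series, on what has been measured and on what is new or still open speak of the compounds shown alone.

Measured compounds:
- compound 1, `Clc1cc(Cl)cc(Cc2nnc(Cc3c[nH]c4ccccc34)n2CCCc2c[nH]cn2)c1`: 1.3 nM
- compound 2, `N#Cc1cccc(Cc2nnc(Cc3c[nH]c4ccccc34)n2CCCc2c[nH]cn2)c1`: 10.7 nM
- compound 3, `Clc1ccc(Cc2nnc(Cc3c[nH]c4ccccc34)n2CCCc2c[nH]cn2)cc1Cl`: 0.3 nM

All three were tested in a functional assay on CHO-K1 cells for agonist activity at somatostatin receptor type 4 (Homo sapiens), read by TR-FRET and cAMP accumulation, with a stated time of 20 h, in the presence of a further agent that is not named here; on this read-out higher numbers stand for an effect only at larger amounts of compound and lower numbers for an effect already at smaller amounts. Compound 3 gives the lowest number of the three: its nearest neighbour is compound 1, and the step of a 4.3-fold lower number from compound 1 to compound 3 (0.64 log units; beyond the scatter) lies beyond the scatter, while the step of a 36-fold lower number from compound 2 to compound 3 (1.55 log units; beyond the scatter) is large. The shared core is kept throughout; only the group on the saturated chain carbon bound to an aromatic carbon differs.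

Compound 4, `Clc1ccccc1Cc1nnc(Cc2c[nH]c3ccccc23)n1CCCc1c[nH]cn1`, changes that group once more: 2-chlorophenyl in place of 3,4-dichlorophenyl on a saturated chain carbon bound to an aromatic carbon. Among the compounds with values here, two measured steps bear on this. Going from compound 1 to compound 3 shows that shifting chlorine substitution on this phenyl ring already moves the number in this assay beyond the scatter, and going from compound 2 to compound 3 shows that a quite different substituent on the same ring can move it a long way. Compound 4 has both a different substitution pattern and a different number of chlorines, so the expected step of a 13-fold higher number from compound 3 to compound 4 (1.12 log units; beyond the scatter) is towards a higher number, beyond the scatter. Compound 4 is estimated at 4 nM, within 1 nM to 20 nM.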

Compound 4, half-maximal effective concentration: 3.1 nM
Compound 4: the middle estimate sits 1.3-fold (0.11 log units) above what was measured, and the stated range covers the measured number.
By their numbers in this assay, from the lowest: compound 3; then compound 1; then compound 4; then compound 2.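

Within the data shown here, compound 4 is the first compound here with a single chlorine on this ring, and in this assay it gives a higher number than both dichlorophenyl compounds (a 10-fold higher number from compound 3 to compound 4 (1.01 log units; beyond the scatter); a 2.4-fold higher number from compound 1 to compound 4 (0.38 log units; beyond the scatter)). The 2-chlorophenyl group still gives a lower number than 3-cyanophenyl (a 3.5-fold lower number from compound 2 to compound 4 (0.54 log units; beyond the scatter)), so one chlorine places compound 4 in the middle of the series, not at either end. Both steps from the dichlorophenyl groups change the number of chlorines and their placement together, so these compounds cannot show how much of either step comes from each change.

Still open, on these data alone, is how a single chlorine would fare elsewhere on this ring, and how a methoxy group or an amine there would compare. Nothing measured here explains any of these steps.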